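Toward compound 4: a carboxyethenyl group replaces cyano

This account rests on a few compounds, and the source may have more. Where it says the series, first, only, none or still open, it means among the compounds named here.

Measured in an ADME assay on MT2 cells (Homo sapiens) for cytotoxicity, read by XTT assay, with a stated time of 4 days; on this read-out lower numbers stand for higher toxicity in this test and higher numbers for lower toxicity in this test:
- compound 1 `Cc1cc(C#N)cc(C)c1Oc1ccc(N)c(Nc2ccc(C#N)cc2)n1` gives > 100000 nM (a limit)
- compound 2 `Cc1cc(/C=C/C#N)cc(C)c1Oc1ccc([N+](=O)[O-])c(Nc2ccc(C#N)cc2)c1` gives > 100000 nM (a limit)
- compound 3 `Cc1cc(/C=C/C#N)cc(C)c1Oc1cc(Nc2ccc(C#N)cc2)c([N+](=O)[O-])cc1[N+](=O)[O-]` gives 21700 nM (a number)

Compound 1 stands at > 100000 nM as a limit of the assay, not a number. Within the data shown here, compound 2 carries the same limit, > 100000 nM, and so the series so far sits mostly at the limit of > 100000 nM in this assay, at which 2 of the 3 values shown sit, in the data. Among the measured compounds shown here, compound 3 is the only one with a number.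

Compound 4 `Cc1cc(/C=C/C(=O)O)cc(C)c1Oc1ccc(N)c(Nc2ccc(C#N)cc2)n1` is not yet measured. Its change from compound 1 is 2-carboxyethenyl in place of cyano on an aromatic carbon, para to a large group: 2-carboxyethenyl in place of cyano on an aromatic carbon in full.

For the measured compounds named here, only one measured step is available, an at least 4.6-fold lower number from compound 2 to compound 3 (0.66 log units; beyond the scatter), and it is a nitro in place of hydrogen on an aromatic carbon, a different change that bears only loosely here. No step beyond the scatter is firmly expected in this assay, though a lower number of that size cannot be excluded. The estimated step of an at least 1.4-fold lower number from compound 1 to compound 4 (0.15 log units; that floor lies within the scatter) stays tied to the limit of compound 1. For compound 4 the estimated value is 70000 nM, with an expected range from 20000 nM to 200000 nM as the likely span.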

Compound 4, half-maximal cytotoxic concentration: 15700 nM
Compound 4: the middle estimate sits 4.5-fold (0.65 log units) above what was measured; measured number outside the range, below it.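

In this assay, replacing cyano with 2-carboxyethenyl on the aromatic carbon para to a large group gives an at least 6.3-fold lower number from compound 1 to compound 4 (0.80 log units; beyond the scatter). Among these compounds, this shows that a change at this position alone, with the rest of the core of compound 1 unchanged, is enough to bring a measurable number into the series, and the only earlier step that could be read was a different change, nitro in place of hydrogen. The size of the new step remains a floor because compound 1 has a limit and not a number: the limit of > 100000 nM in this assay, at which 2 of the 4 values shown sit.

The compounds shown do not separate the contribution of the carboxylic acid from that of the ethenyl chain that carries it. A methyl ester or a primary amide at the end of the chain, or a saturated propanoic acid chain at the same position, would address that question.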